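The source may hold more compounds than are shown below. What is called first, only, known or untested is meant among the compounds shown, and "the series" means these compounds.

In a functional assay on Ehrlich cells (Mus musculus) for cytotoxicity, tested at 100 ug/mL (on this read-out lower numbers stand for a weaker effect and higher numbers for a stronger effect at the one concentration tested), compound 1 `COc1cc(N2C(N)=C(C#N)C(/C=C/c3ccccc3)C3=C2CC(C)(C)CC3=O)cc(OC)c1OC` gives 40%. For the measured compounds named here, compound 2 `COc1cc(N2C(N)=C(C#N)C(c3ccccc3O)C3=C2CC(C)(C)CC3=O)cc(OC)c1OC` gives 10%, the lowest of the two numbers so far; that change, a number 30 percentage points lower from compound 1 to compound 2 (beyond the scatter), came from 2-hydroxyphenyl in place of 2-phenylethenyl on a saturated ring carbon. Compound 3 `COc1cc(N2C(N)=C(C#N)C(c3ccc(OC)c4ccccc34)C3=C2CC(C)(C)CC3=O)cc(OC)c1OC` differs from compound 2 by 4-methoxynaphthalen-1-yl in place of 2-hydroxyphenyl on a saturated ring carbon. Going by the values given here, only that one measured step touches the same saturated ring carbon, and no step swaps one aromatic ring for another, so little can be read from it. A small shift is therefore expected, a number 8 percentage points higher from compound 2 to compound 3 (within the scatter). Compound 3 is estimated at 18%, within 5% to 45%.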

Compound 3, a percentage reported as activity, at one concentration (the size of the read-out at that concentration, not a potency): 40%
Compound 3: middle estimate off by 22 percentage points, on the low side; measured number inside the range.
By their numbers in this assay, from the lowest: compound 2; then compounds 1 and 3 (each within the scatter of the next).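

In this assay, putting 4-methoxynaphthalen-1-yl in place of 2-hydroxyphenyl on the saturated ring carbon gives a number 30 percentage points higher from compound 2 to compound 3 (beyond the scatter) and shows that exchanging one aromatic group for another here can move the read-out. Putting it in place of 2-phenylethenyl gives no change at the digits printed from compound 1 to compound 3 (within the scatter) and so leaves compound 2 alone at the low end. Nothing measured here explains this difference.

Compound 2 and compound 3 differ in both the hydroxyl and the second ring, and the shown compounds do not separate these two changes. From the compounds shown here alone, how a plain phenyl or a 2-methoxyphenyl group would read at this carbon remains open.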